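From methyl to dimethylamino on an aromatic carbon

The source may report more compounds than this note shows. Statements on the series, on what has been measured and on what is new or still open speak of the compounds shown alone.

In a functional assay on HeLa cells (Homo sapiens) for cytotoxicity, read by MTT assay, with a stated time of 48 h (a higher number here means a weaker inhibitor, a lower number a stronger inhibitor), compound 1 (`COc1cc(/C=C/C(=O)C2=C(/C=C/c3ccc(O)c(OC)c3)NC(=O)NC2c2ccccc2)ccc1O`) gives 100000 nM, and compound 2 (`COc1cc(/C=C/C(=O)C2=C(/C=C/c3ccc(O)c(OC)c3)NC(=O)NC2c2ccc(C)cc2)ccc1O`) gives 100000 nM. Compound 3 (`COc1cc(/C=C/C(=O)C2=C(/C=C/c3ccc(O)c(OC)c3)NC(=S)NC2c2ccc(C)cc2)ccc1O`) has the lowest number of the three at 25000 nM, beyond the scatter from both. Compound 4 (`COc1cc(/C=C/C(=O)C2=C(/C=C/c3ccc(O)c(OC)c3)NC(=S)NC2c2ccc(N(C)C)cc2)ccc1O`) carries dimethylamino in place of methyl on an aromatic carbon, para to a large group: dimethylamino in place of methyl on an aromatic carbon. Within the data shown here, the one measured step on an aromatic carbon shows no change at the digits printed from compound 1 to compound 2 (within the scatter), with methyl in place of hydrogen. Among the measured compounds shown here, no measured step brings in dimethylamino. For the measured compounds named here, with only that step as a guide, no change beyond the scatter is expected in this assay, in either direction. The estimate means an expected no change at the digits printed from compound 3 to compound 4 (within the scatter). Compound 4 is expected at 25000 nM, with an estimated range of 8000 nM to 80000 nM.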

Compound 4, half-maximal inhibitory concentration: 12500 nM
Compound 4: the middle estimate sits 2.0-fold (0.30 log units) above what was measured; low and high end bracket the measured number.
By their numbers in this assay, from the lowest: compounds 4 and 3 (each within the scatter of the next); then compounds 1 and 2 (each within the scatter of the next).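

In this assay, the change from 4-methylphenyl to 4-(dimethylamino)phenyl gives a 2.0-fold lower number from compound 3 to compound 4 (0.30 log units; within the scatter), so the two compounds cannot be told apart. The earlier step at this position only replaced hydrogen with methyl, and at the digits printed it began from a value shared by both compounds. This step shows that a group of more heavy atoms, including a nitrogen and a hydrogen-bond acceptor, also leaves the number within the scatter on the core of compound 3.

As far as these compounds go, whether a carboxylic acid or a longer chain here would move the number beyond the scatter remains open, as does how dimethylamino would read on the core of compound 1. Nothing measured here accounts for this result.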